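The source may hold more compounds than are shown below. What is called first, only, known or untested is meant among the compounds shown, and "the series" means these compounds.

The compounds share one core, seen in compound 1 `C=CC1=C(C(=O)NCc2ccc(Cl)cc2)C(c2ccc(OC)cc2)OC1`. In a functional assay on HeLa cells (Homo sapiens) for cytotoxicity, read by MTT assay, with a stated time of 24 h (a higher number here means a weaker inhibitor, a lower number a stronger inhibitor), compound 1 sits at the assay limit and gives > 100000 nM. Compound 2 `C=CC1=C(C(=O)NC2CCCCC2)C(c2ccc(OC)cc2)OC1` gives 24800 nM in this assay. Compound 3 `C=CC1=C(C(=O)NCC(C)C)C(c2ccc(OC)cc2)OC1` also sits at the assay limit in this assay, with > 100000 nM. The measured steps are an at least 4.0-fold lower number from compound 1 to compound 2 (0.60 log units; beyond the scatter), an at least 4.0-fold higher number from compound 2 to compound 3 (0.60 log units; beyond the scatter) and a step that the two limits leave unreadable from compound 1 to compound 3. Compound 3 thus stands at a limit, shared by the limit of > 100000 nM in this assay, at which 2 of the 3 values shown sit. Compound 4 `C=CC1=C(C(=O)NCc2ccccc2F)C(c2ccc(OC)cc2)OC1` differs from compound 3 by 2-fluorophenyl in place of isopropyl on a saturated chain carbon bound to an amide-type nitrogen. Among the measured compounds shown here, only the step from compound 1 to compound 3 bears on this change, and it is unreadable; compound 1, with an aromatic ring at the same place, sits at the same limit. For compound 4 in this assay a number is expected near 150000 nM, between 50000 nM and 600000 nM. The expected step is a step that the limit leaves unreadable from compound 3 to compound 4, most likely read again as a limit.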

Compound 4, half-maximal inhibitory concentration: > 100000 nM
Compound 4: a limit, no number; the forecaster's own chance of this, stated with the estimate: 75%; the middle value does not contradict the limit.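

In this assay compound 4, with 2-fluorobenzyl on the amide nitrogen, gives > 100000 nM, which is a limit of the assay and not a number. Among the compounds shown here, putting 2-fluorobenzyl in place of cyclohexyl gives an at least 4.0-fold higher number from compound 2 to compound 4 (0.60 log units; beyond the scatter), so cyclohexyl remains the only group here with a measured number. The steps from compound 1 and from compound 3 to compound 4 cannot be read, and compound 4 joins the shared limit: the limit of > 100000 nM in this assay, at which 3 of the 4 values shown sit.

Going by these compounds, whether a cyclopentyl or cycloheptyl ring on the amide nitrogen would also give a measured number stays open. On these data alone, how far compound 1, compound 3 and compound 4 differ beyond their shared limit also stays open.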